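A few compounds are considered here, and "the series" means these few. Any claim that something is new, unique, unknown or untested is made for them only; others in the source may bear on it.

In a functional assay (aorta) with Rattus norvegicus as the target (a higher number here means that more compound is needed for the effect, a lower number that less compound is needed), three compounds have been tested so far. Compound 1 (`CNC1=NS(=O)(=O)c2cc(F)ccc2N1`) gives > 300 uM, which is a limit of the assay and not a number. Compound 2 (`CCNC1=NS(=O)(=O)c2cc(F)ccc2N1`) gives > 300 uM, which is also a limit. Among the measured compounds shown here, compound 3 (`CNC1=NS(=O)(=O)c2cc(Cl)ccc2N1`) gives 142 uM, the only actual number among the three.

Compound 4 (`CCC(C)NC1=NS(=O)(=O)c2cc(Cl)ccc2N1`) has not yet been measured. It differs from compound 3 by sec-butyl in place of methyl on an amine nitrogen.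

The closest evidence is a change on this same amine chain, a step that the two limits leave unreadable from compound 1 to compound 2, so it fixes neither size nor direction. The other measured change is an at least 2.1-fold lower number from compound 1 to compound 3 (0.32 log units; beyond the scatter), and compound 4 keeps that chloro. The swap is a large one, so a clear step to a lower number in this assay is expected rather than none, though this expectation is uncertain and a limit remains possible. The expected change is a 3.6-fold lower number from compound 3 to compound 4 (0.55 log units; beyond the scatter). For compound 4, the estimated value is 40 uM, with an expected range from 10 uM to 200 uM.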

Compound 4, concentration for half-maximal effect: 15.5 uM
Compound 4: middle estimate off by 2.6-fold (0.41 log units), on the high side; the measured number falls inside the stated range.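

In this assay, the amine nitrogen proves to be a place where the chain matters: sec-butyl in place of methyl gives a 9.2-fold lower number from compound 3 to compound 4 (0.96 log units; beyond the scatter). The earlier step on this chain cannot be read, because compound 1 and compound 2 both sit at a limit of the assay: the limit of > 300 uM in this assay, at which 2 of the 4 values shown sit. The chloro pair therefore supplies the first readable direction at this position, with the four-carbon chain giving the lower number, though it is a single pair of compounds.

Going by these compounds, it remains open whether the number keeps falling with a longer chain such as straight-chain hexyl or with a ring such as cyclohexyl on this nitrogen. On these data alone, it is also open whether sec-butyl would give a similar step on the fluoro version of the shared core.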